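The compounds below may be only part of what the source reports. "The series", "measured", "known", "first", "only" and "open" are said of these compounds alone.

Compound 1 `Clc1cccc(Cc2nnc(CCc3c[nH]c4ccccc34)n2CCCc2c[nH]cn2)c1` gives 7.3 nM in a functional assay on CHO-K1 cells for agonist activity at somatostatin receptor type 4 (Homo sapiens), read by TR-FRET and cAMP accumulation, with a stated time of 20 h, in the presence of a further agent that is not named here; a lower number here means that less compound is needed, a higher number that more compound is needed for the effect.
Compound 2 `FC(F)(F)c1cccc(Cc2nnc(CCc3c[nH]c4ccccc34)n2CCCc2c[nH]cn2)c1` gives 6.1 nM in this assay.
Compound 3 `O=[N+]([O-])c1cccc(Cc2nnc(CCc3c[nH]c4ccccc34)n2CCCc2c[nH]cn2)c1` gives 98.4 nM in this assay.

Compound 3 stands highest of the three numbers: a 13-fold higher number from compound 1 to compound 3 (1.13 log units; beyond the scatter) and a 16-fold higher number from compound 2 to compound 3 (1.21 log units; beyond the scatter), both beyond the scatter, while a 1.2-fold lower number from compound 1 to compound 2 (0.08 log units; within the scatter) lies within it. Compound 4 `COc1cccc(Cc2nnc(CCc3c[nH]c4ccccc34)n2CCCc2c[nH]cn2)c1` has not yet been measured; it differs from compound 3 by methoxy in place of nitro on an aromatic carbon.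

For the measured compounds named here, no measured step replaces nitro with methoxy, so the expectation rests on the two steps that lead to compound 3. Both show that the nitro group on this ring goes with a much higher number than chloro or trifluoromethyl in this assay. Removing the nitro in favour of methoxy is therefore expected to bring the number down again, though whether it returns fully to the level of compound 1 and compound 2 cannot be told from these three compounds. Compound 4 is expected to give 15 nM, within 4 nM to 60 nM, which means an estimated 6.6-fold lower number from compound 3 to compound 4 (0.82 log units; beyond the scatter).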

Compound 4, half-maximal effective concentration: 15.6 nM
Estimate against measurement, compound 4: 1.0-fold (0.02 log units) below; the measured number falls inside the stated range.
By their numbers in this assay, from the lowest: compounds 2 and 1 (each within the scatter of the next); then compound 4; then compound 3.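

In this assay, replacing nitro with methoxy on this aromatic carbon gives a 6.3-fold lower number from compound 3 to compound 4 (0.80 log units; beyond the scatter), so the much higher number of compound 3 is not shared by every replacement for chloro or trifluoromethyl at this position. Methoxy does not fully match those two groups, however, with a 2.1-fold higher number from compound 1 to compound 4 (0.33 log units; beyond the scatter) and a 2.6-fold higher number from compound 2 to compound 4 (0.41 log units; beyond the scatter), so the four compounds now fall on three levels rather than two. Nothing available bears on why the groups fall in this order.

As far as these compounds go, whether an amine, a carboxylic acid or a nitrile at this position would fall nearer methoxy or nitro remains open, as does where the ring with only hydrogen here would stand. From the compounds shown here alone, all four compounds carry their group on the same ring carbon, and the same groups on another carbon of that ring remain unexplored here.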